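Aryl thioether variation on the sulfur of the series

The compounds below may be only part of what the source reports. "The series", "measured", "known", "first", "only" and "open" are said of these compounds alone.

Among the compounds with values here, compound 2 `Cc1cc(C)cc(SCc2ccc(/C=C/C(=O)Nc3ccccc3N)cc2)c1` gives the lower of the two numbers so far in a functional assay on HeLa cells (Homo sapiens) for inhibition, read by CCK-8 assay, with a stated time of 72 h, tested at 8 uM (a lower number here means less inhibition of growth, a higher number more inhibition of growth at the concentration tested), at 3.39%. Compound 1 `Cc1ccc(SCc2ccc(/C=C/C(=O)Nc3ccccc3N)cc2)cc1` gives 21.7% in this assay; the step of a number 18.3 percentage points lower from compound 1 to compound 2 (beyond the scatter) is the only one measured. Compound 3 `Nc1ccccc1NC(=O)/C=C/c1ccc(CSc2cccc3ccccc23)cc1`, not yet measured, differs from compound 2 by naphthalen-1-yl in place of 3,5-dimethylphenyl on a sulfur. Within the data shown here, no measured step exchanges an aryl group for naphthalen-1-yl on a sulfur; the one step known shows only that changing the group there can move the number beyond the scatter, so the direction for compound 3 is open. Compound 3 is expected at 15%, range 0% to 35%, a step of a number 11.6 percentage points higher from compound 2 to compound 3 (beyond the scatter).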

Compound 3, percent growth inhibition at one concentration: 22.1%
Estimate against measurement, compound 3: 7.1 percentage points below, within the range that was stated.
By their numbers in this assay, from the lowest: compound 2; then compounds 1 and 3 (each within the scatter of the next).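

In this assay, naphthalen-1-yl in place of 3,5-dimethylphenyl on the sulfur gives a number 18.7 percentage points higher from compound 2 to compound 3 (beyond the scatter), so the number at this position does not fall with the larger carbon count of the entering group. Against 4-methylphenyl, the same group gives a number 0.4 percentage points higher from compound 1 to compound 3 (within the scatter), leaving compound 1 and compound 3 not separable here. The data offered give no explanation for these differences among the aryl groups. From the compounds shown here alone, whether a cyclohexyl group or a longer alkyl chain on the sulfur holds the number remains open, as does the effect of an amine or carboxylic acid on the aryl ring.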